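The source may hold more compounds than are shown below. What is called first, only, known or untested is meant among the compounds shown, and "the series" means these compounds.

In a functional assay on ZR-75-1 cells (Homo sapiens) for inhibition, read by sulforhodamine B assay (on this read-out higher numbers stand for weaker inhibition of growth and lower numbers for stronger inhibition of growth), compound 1 `FC(F)(F)Oc1ccc(-c2ccc(-c3ccc(-c4nc5ccccc5[nH]4)cc3)cc2)cc1` gives 100000 nM, compound 2 `Oc1cccc2[nH]c(-c3ccc(-c4ccc(-c5ccc(F)cc5)cc4)cc3)nc12` gives 6320 nM, and compound 3 `Oc1cccc2[nH]c(-c3ccc(-c4ccc(-c5ccc(C(F)(F)F)cc5)cc4)cc3)nc12` gives 5110 nM. Compound 3 and compound 2 therefore lie within the scatter of each other, and the number for compound 1 lies well beyond the scatter from both.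

Compound 4 `Oc1cccc2[nH]c(-c3ccc(-c4ccc(-c5ccc(OC(F)(F)F)cc5)cc4)cc3)nc12` has not yet been measured. It differs from compound 3 by a single change, trifluoromethoxy in place of trifluoromethyl on an aromatic carbon.

For the measured compounds named here, one measured step bears on this change, since it also swaps the group on that aromatic carbon. This is a 1.2-fold lower number from compound 2 to compound 3 (0.09 log units; within the scatter), and it stays within the scatter. Going by the values given here, it is only a single pair, and no measured pair shows trifluoromethoxy against another group on the shared core of compound 3. Compound 1 does carry trifluoromethoxy, but on a different core, so it gives only a loose warning for the high side of the range.

No step beyond the scatter is therefore expected in this assay. The expected step is a 1.1-fold higher number from compound 3 to compound 4 (0.03 log units; within the scatter), with no clear direction. For compound 4 the estimated value is 5500 nM, with an expected range from 2000 nM to 16000 nM.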

Compound 4, concentration for 50% growth inhibition: 3800 nM
Beside the measured number, compound 4's estimate is 1.4-fold (0.16 log units) above it, and the stated range covers the measured number.
By their numbers in this assay, from the lowest: compounds 4, 3 and 2 (each within the scatter of the next); then compound 1.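

In this assay trifluoromethoxy on this aromatic carbon, para to a large group, stays level with both groups already seen there: the swap from trifluoromethyl gives one step (a 1.3-fold lower number from compound 3 to compound 4 (0.13 log units; within the scatter)) and the swap from fluoro gives another (a 1.7-fold lower number from compound 2 to compound 4 (0.22 log units; within the scatter)), so all three groups on the shared core lie within the scatter of one another. For the compounds shown here, the new compound also forms a pair with compound 1 that holds trifluoromethoxy constant, and hydroxy in place of hydrogen on an aromatic carbon gives the only large step among the new ones (a 26-fold lower number from compound 1 to compound 4 (1.42 log units; beyond the scatter)), which ties the high number of compound 1 to that difference and not to the trifluoromethoxy group. Nothing on hand gives a reason for either result.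

The compounds shown leave open whether an amine, a carboxylic acid or a longer chain on this aromatic carbon would move the number beyond the scatter. They also leave open whether the hydroxy step would be of the same size with fluoro or trifluoromethyl in place of trifluoromethoxy.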